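Fluorines for methyls in a fatty acid receptor agonist

The compounds below may be only part of what the source reports. "The series", "measured", "known", "first", "only" and "open" are said of these compounds alone.

Compound 1, `CC#CC(CC(=O)O)c1ccc(OCc2ccc3nc(-c4ccc(F)cc4F)cn3c2)cc1`: 825 nM
Compound 2, `CC#CC(CC(=O)O)c1ccc(OCc2ccc3nc(-c4ccc(CC)cc4)cn3c2)cc1`: 496 nM
Compound 3, `CC#CC(CC(=O)O)c1ccc(OCc2ccn3cc(-c4ccc(C)cc4C)nc3c2)cc1`: 503 nM

All three were measured in an assay on isolated protein for agonist activity at Free fatty acid receptor 1 (Homo sapiens); on this read-out higher numbers stand for an effect only at larger amounts of compound and lower numbers for an effect already at smaller amounts. Compound 3 stands second highest of the three numbers; its nearest neighbour is compound 2 and its furthest is compound 1, both gaps within the scatter. Compound 4, `CC#CC(CC(=O)O)c1ccc(OCc2ccn3cc(-c4cc(F)ccc4F)nc3c2)cc1`, differs from compound 3 by 2,5-difluorophenyl in place of 2,4-dimethylphenyl on an aromatic carbon. Going by the values given here, the one measured step, a 1.7-fold lower number from compound 1 to compound 2 (0.22 log units; within the scatter), replaced a difluorophenyl with an alkyl-bearing phenyl and stayed within the scatter; the change to compound 4 runs the opposite way, methyls giving way to fluorines, so compound 4 is expected to move by no more than the scatter, a 1.4-fold higher number from compound 3 to compound 4 (0.14 log units; within the scatter), if anything toward a higher number. Compound 4 is therefore estimated at 700 nM, within 350 nM to 1400 nM.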

Compound 4, half-maximal effective concentration: 639 nM
Compound 4: the middle estimate sits 1.1-fold (0.04 log units) above what was measured; the range from low to high includes it.
By their numbers in this assay, from the lowest: compounds 2, 3, 4 and 1 (each within the scatter of the next).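

Exchanging the two substituted phenyl groups on the aromatic carbon next to the ring nitrogen gives, in this assay, a 1.3-fold higher number from compound 3 to compound 4 (0.10 log units; within the scatter). Going by these compounds alone, this is the first step read on the core of compound 3, and it shows that 2,4-dimethylphenyl and 2,5-difluorophenyl are not told apart at this position. No accompanying measurement bears on this result. Still open, going by these compounds, is whether a group other than a substituted phenyl at this position, such as an amine or a longer alkyl chain, would take the number beyond the scatter.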